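This account rests on a few compounds, and the source may have more. Where it says the series, first, only, none or still open, it means among the compounds named here.

Four compounds share one core and differ in the group on a sulfonyl sulfur: compound 1 `COc1ccc(S(=O)(=O)n2cc(/C=C/C(=O)c3ccncc3)c3ccccc32)cc1`, compound 2 `O=C(/C=C/c1cn(S(=O)(=O)c2cccc3ccccc23)c2ccccc12)c1ccncc1`, compound 3 `O=C(/C=C/c1cn(S(=O)(=O)c2ccc(Cl)cc2Cl)c2ccccc12)c1ccncc1` and compound 4 `O=C(/C=C/c1cn(S(=O)(=O)c2ccc(Cl)cc2)c2ccccc12)c1ccncc1`. In a functional assay on MCF7 cells (Homo sapiens) for antiproliferative activity, read by MTT assay, with a stated time of 48 h (on this read-out higher numbers stand for weaker inhibition and lower numbers for stronger inhibition), compound 1 gives 65800 nM and compound 2 gives 58000 nM. The step of a 1.1-fold lower number from compound 1 to compound 2 (0.05 log units; within the scatter) means that compound 2 stands level with compound 1. Compound 3 gives 12200 nM; "dose-dependent effect" (no number reported) (2 entries), a lower number than those of the other two.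

The change to consider is 4-chlorophenyl in place of naphthalen-1-yl on a sulfonyl sulfur, with 4-chlorophenyl in place of naphthalen-1-yl on a sulfonyl sulfur. For the measured compounds named here, no measured step makes this exact swap. The step from compound 1 to compound 2 suggests that exchanging these groups need not move the number much. Going by the values given here, compound 3, the only measured compound holding chlorine, gives 12200 nM; "dose-dependent effect" (no number reported) (2 entries), which points the other way, so a moderate move toward stronger inhibition seems likely, though this rests on one compound. In this assay, the expected step is a 2.1-fold lower number from compound 2 to compound 4 (0.32 log units; beyond the scatter). For compound 4 the estimate is 28000 nM, with an expected range of 11000 nM to 65000 nM.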

Compound 4, half-maximal inhibitory concentration: 37500 nM
Beside the measured number, compound 4's estimate is 1.3-fold (0.13 log units) below it; low and high end bracket the measured number.
By their numbers in this assay, from the lowest: compounds 4, 2 and 1 (each within the scatter of the next).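

In this assay, 4-chlorophenyl in place of naphthalen-1-yl gives a 1.5-fold lower number from compound 2 to compound 4 (0.19 log units; within the scatter), and chloro in place of methoxy gives a 1.8-fold lower number from compound 1 to compound 4 (0.24 log units; within the scatter). On a sulfonyl sulfur whose other neighbour is an aromatic nitrogen, a methoxy-bearing ring, a chlorine-bearing ring and the two-ring naphthalen-1-yl therefore all stand level, so neither one chlorine nor the loss of a ring moves the number beyond the scatter. Compound 3, which carries a second chlorine, still stands alone with its lower printed number, and that number comes from a mixed record: the several entries of compound 3 in this assay, 12200 nM; "dose-dependent effect" (no number reported) (2 entries)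

For the compounds shown here, whether the second chlorine itself accounts for the number of compound 3 stays open, with only that one compound carrying it. Also open, going by these compounds, is how an amine or a carboxylic acid on the ring attached to the sulfonyl sulfur would read.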